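Bromo to Fluoro Exchange on Two Related Cores

A few compounds are considered here, and "the series" means these few. Any claim that something is new, unique, unknown or untested is made for them only; others in the source may bear on it.

Measured in a functional assay on Huh-7 cells (Homo sapiens) for inhibition, read by sulforhodamine B assay, with a stated time of 72 h; a higher number here means a weaker inhibitor, a lower number a stronger inhibitor:
compound 1, `COc1ccc2cc(C(C)c3nnc4n3N=C(c3ccc(Br)cc3)CS4)ccc2c1`, gives 9300 nM
compound 2, `COc1ccc2cc(C(C)c3nnc4n3N=C(c3ccc(F)cc3)CS4)ccc2c1`, gives 7000 nM
compound 3, `CC(c1ccc(-c2ccccc2)c(F)c1)c1nnc2n1N=C(c1ccc(Br)cc1)CS2`, gives 5000 nM

Compound 2 differs from compound 1 by fluoro in place of bromo on an aromatic carbon, and this change made a step of a 1.3-fold lower number from compound 1 to compound 2 (0.12 log units; within the scatter). The difference between the core of compound 1 and the core of compound 3 is not broken down here. Compound 4, `CC(c1ccc(-c2ccccc2)c(F)c1)c1nnc2n1N=C(c1ccc(F)cc1)CS2`, carries the same change relative to compound 3, namely (fluoro in place of bromo on an aromatic carbon), at a place described in the same words. Because the earlier step of a 1.3-fold lower number from compound 1 to compound 2 (0.12 log units; within the scatter) was small, compound 4 is expected to sit close to compound 3, and the estimated step is a 1.3-fold lower number from compound 3 to compound 4 (0.12 log units; within the scatter). Compound 4 is therefore estimated at 3800 nM in this assay, expected to fall between 1600 nM and 9000 nM.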

Compound 4, half-maximal inhibitory concentration: 4900 nM
The estimate for compound 4 lay 1.3-fold (0.11 log units) below the measured number, and the stated range covers the measured number.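

In this assay, the exchange of 4-bromophenyl for 4-fluorophenyl on the second core gave a 1.0-fold lower number from compound 3 to compound 4 (0.01 log units; within the scatter). Set beside the first core, the two steps agree: the same change on two cores in this assay, a 1.3-fold lower number (0.12 log units; within the scatter) from compound 1 to compound 2 and a 1.0-fold lower number (0.01 log units; within the scatter) from compound 3 to compound 4, 1.3-fold (0.11 log units) apart, within the scatter of two such steps This shows that the exchange carried from the core of compound 1 to the core of compound 3 without a readable difference, but as neither step lies beyond the scatter, it shows no effect of the exchange on either core and says nothing of cores outside these two.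

The compounds shown leave open how an amine or a carboxylic acid in place of the bromo or fluoro would read. They also leave open whether a methoxy group there would give a step beyond the scatter.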